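The compounds below may be only part of what the source reports. "The series", "measured", "known", "first", "only" and "open" are said of these compounds alone.

Compound 1 `CCCc1nc(-c2ccccc2)c(CNCCCN2CCN(c3cccc(F)c3)CC2)o1` is measured in an assay on HEK293 cells for inhibition of Voltage-dependent T-type calcium channel subunit alpha-1G (Homo sapiens), read by patch clamp (a lower number here means a stronger inhibitor, a higher number a weaker inhibitor), where compound 1 gives 3030 nM. Within the data shown here, of the three compounds measured so far it stands second highest. Compound 2 `CCCc1nc(-c2ccccc2)c(CNCCN2CCN(c3cccc(F)c3)CC2)o1` gives 3350 nM in this assay, a number within the scatter of compound 1. Compound 3 `CCCc1nc(-c2ccccc2)c(CNCCN2CCN(c3cccc(C)c3C)CC2)o1` gives 1710 nM in this assay, and that number too lies within the scatter of compound 1.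

Compound 4 `CCCc1nc(-c2ccccc2)c(CNCCCN2CCN(c3ccc(Cl)cc3)CC2)o1` has not yet been measured in this assay. It differs from compound 1 in a single place: 4-chlorophenyl in place of 3-fluorophenyl on an amine nitrogen in a ring.

Among the measured compounds shown here, only one measured step bears on this change, because it is the one step that exchanges the aryl group on that same ring nitrogen: a 2.0-fold lower number from compound 2 to compound 3 (0.29 log units; within the scatter). For the measured compounds named here, that step did not rise above the scatter, and nothing among the measured compounds speaks to a move of a halogen from the 3-position to the 4-position of that phenyl. The expectation for compound 4 is therefore a step of a 1.1-fold lower number from compound 1 to compound 4 (0.05 log units; within the scatter), that is, nothing that should be read as a real change in either direction. The estimate for compound 4 in this assay is 2700 nM, with a range from 1200 nM to 6000 nM.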

Compound 4, half-maximal inhibitory concentration: 1310 nM
Compound 4: the middle estimate sits 2.1-fold (0.31 log units) above what was measured, and the stated range covers the measured number.
By their numbers in this assay, from the lowest: compounds 4, 3, 1 and 2 (each within the scatter of the next, the first and the last beyond it).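

In this assay, putting 4-chlorophenyl in place of 3-fluorophenyl on the amine nitrogen in the ring gives a 2.3-fold lower number from compound 1 to compound 4 (0.36 log units; beyond the scatter). Among these compounds, this is a modest step, but unlike the only earlier exchange of the aryl group at this nitrogen, a 2.0-fold lower number from compound 2 to compound 3 (0.29 log units; within the scatter), it lies beyond the scatter, so the compounds now show that the aryl group at this position can shift the number measurably. The two groups match in heavy-atom count and in their counts of hydrogen-bond donors and acceptors, so those counts do not separate them, and no measurement at hand accounts for the step.

From the compounds shown here alone, the exchange alters both the halogen and its place on the phenyl ring, and how much each contributes stays open: 3-chlorophenyl and 4-fluorophenyl would be the groups that separate the two. Going by these compounds, it is also open whether 4-chlorophenyl would give a similar step on the shorter chain of compound 2, and where an unsubstituted phenyl would fall relative to compound 1 and compound 4.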